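Step from compound 2 to compound 4 in the series

This account rests on a few compounds, and the source may have more. Where it says the series, first, only, none or still open, it means among the compounds named here.

Measured compounds:
compound 1 `C=CCN1c2c(n(C)c(=O)n(C)c2=O)NC1N/N=C/c1ccc(O)cc1O`, 340 nM
compound 2 `Cc1nn(-c2ncnc3nc[nH]c23)c2c1C(OCc1ccc(Cl)cc1Cl)CC(=O)N2`, 4 nM
compound 3 `C/C(=N\NC(=O)c1cc2ccccc2cc1O)c1ccc(N)cc1`, 1100 nM

Going by the values given here, compound 1, compound 2 and compound 3 share no single core, and no pair among them differs in one place only, so their numbers can only be set side by side. In a functional assay on HEK293 cells for agonist activity at G-protein coupled receptor 39 (Homo sapiens), read by scintillation proximity assay and inositol phosphate accumulation, with a stated time of 75 min, in the presence of a further agent that is not named here (on this read-out higher numbers stand for an effect only at larger amounts of compound and lower numbers for an effect already at smaller amounts), compound 2 gives 4 nM, the lowest of the three numbers. Compound 1 gives a number that stands well above it, beyond the scatter, and compound 3 gives the highest number of the three, again beyond the scatter from compound 2. Nothing further can be read across these three structures.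

Compound 4 `Cc1nn(-c2ncnc3nc[nH]c23)c2c1C(OCC(C)C)CC(=O)N2` has not been measured. It keeps the core of compound 2 and differs from it in one place: isopropyl in place of 2,4-dichlorophenyl on a saturated chain carbon bound to an oxygen on a saturated carbon. The change removes one six-membered aromatic ring of carbon only with two chlorine atoms and puts a chain of three carbon atoms in its place. Among the compounds with values here, no measured pair in the set shows what such a change does in this assay, so the expectation rests on the size of the group lost. A step upward, beyond the scatter, is expected, a 50-fold higher number from compound 2 to compound 4 (1.70 log units; beyond the scatter). Compound 4 is therefore estimated at 200 nM, within a range from 25 nM to 2000 nM.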

Compound 4, half-maximal effective concentration: 4 nM
For compound 4 the middle estimate is 50-fold (1.70 log units) above the measured one; measured number below the stated range.
By their numbers in this assay, from the lowest: compounds 2 and 4 (each within the scatter of the next); then compound 1; then compound 3.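

In this assay, going by these compounds alone, the exchange of 2,4-dichlorophenyl for isopropyl, on a saturated chain carbon bound to an oxygen on a saturated carbon, gives no change at the digits printed from compound 2 to compound 4 (within the scatter) and is the only step that can be read at a single place. At this position, the shared core holds its number without the six-membered aromatic ring and its two chlorine atoms, so an aromatic ring on this chain is not needed for a number at this level, and 8 heavy atoms leaving against 3 entering makes no difference that can be read on this pair. Nothing at hand bears on why the two groups read alike.

The compounds shown leave open how far this tolerance reaches: whether a carboxylic acid or an amine at the end of the chain, or a longer chain such as octyl, would keep the number at this level. From the compounds shown here alone, with one pair on one core, it also remains open whether methyl in place of isobutyl would do the same, and whether the exchange reads alike on any other core.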